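A few compounds are considered here, and "the series" means these few. Any claim that something is new, unique, unknown or untested is made for them only; others in the source may bear on it.

Measured in a functional assay on HepG2 cells (Homo sapiens) for antiproliferative activity, read by MTT assay, with a stated time of 72 h; a higher number here means a weaker inhibitor, a lower number a stronger inhibitor:
- Compound 1 `O=C1O/C(=C\Cn2cnc3c(F)nc(F)c(Cl)c32)C(OCc2ccccc2)=C1OCc1ccccc1`: > 100000 nM
- Compound 2 `O=C1O/C(=C\Cn2cnc3ccn(C/C=C4\OC(=O)C(OCc5ccccc5)=C4OCc4ccccc4)c3c2=O)C(OCc2ccccc2)=C1OCc1ccccc1`: > 100000 nM
- Compound 3 `O=C1NC(O)(CCn2cnc3cc[nH]c3c2=O)C(OCc2ccccc2)=C1OCc1ccccc1`: > 100000 nM

Compound 1 gives no number in this assay, only a limit of the assay, > 100000 nM. Compound 2 likewise reaches only a limit, > 100000 nM. Compound 3 also reaches only a limit, > 100000 nM. The whole set therefore stands in one place: the limit of > 100000 nM in this assay, at which 3 of the 3 values shown sit. No ranking can be drawn among these compounds, and no measured step links any two of them.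

The next compound is compound 4 `O=C1O/C(=C\Cn2cnc3cc[nH]c3c2=O)C(OCc2ccccc2)=C1OCc1ccccc1`, which departs from compound 1 by one exchange: a group of 10 heavy atoms (6 carbon, 3 nitrogen, 1 oxygen; one five-membered aromatic ring with 1 hetero atom, one six-membered aromatic ring with 2 hetero atoms) in place of a group of 12 heavy atoms (6 carbon, 3 nitrogen, 2 fluorine, 1 chlorine; one five-membered aromatic ring with 2 hetero atoms, one six-membered aromatic ring with 1 hetero atom), on a saturated chain carbon bound to a double-bonded chain carbon. The group that enters is already present in compound 3, on a different framework, and compound 3 still shows only the limit > 100000 nM. On that basis, no step beyond the usual scatter is expected in this assay, and a reading at the same limit is the most likely outcome. If a number does appear, it is expected to lie on the stronger side of that limit, but only slightly. The estimated size of the change is a number no higher from compound 1 to compound 4 (the limit leaves the size open). For compound 4 the expected value is 100000 nM, with an estimated range from 30000 nM to 200000 nM.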

Compound 4, half-maximal inhibitory concentration: > 100000 nM
Compound 4 was reported as a limit (the forecaster's own chance of this, stated with the estimate: 80%); the middle value sits exactly at the limit.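

In this assay compound 4 reaches only a limit, > 100000 nM. Compound 1 is also reported only as a limit, so no step can be read from compound 1 to compound 4, and the set stays in one place: the limit of > 100000 nM in this assay, at which 4 of the 4 values shown sit.

The compounds shown leave open whether any of them differs from another in strength, and which structural change would yield a number in this assay.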